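Swapping a Benzylamine Link for a Phenoxy Link

The source may report more compounds than this note shows. Statements on the series, on what has been measured and on what is new or still open speak of the compounds shown alone.

Compound 1 `Nc1cc(N)c2nc(-c3ccccc3)c(NCc3ccc(F)cc3)nc2c1` carries a (4-fluorobenzyl)amino group on its core. In a functional assay on LOX IMVI cells (Homo sapiens) for inhibition, read by sulforhodamine B assay, with a stated time of 48 h (on this read-out lower numbers stand for stronger inhibition of growth and higher numbers for weaker inhibition of growth), compound 1 gives 3160 nM, the lowest of the two numbers recorded so far. Going by the values given here, its only measured neighbour is compound 2 `COc1ccc(CNc2nc3cc(N)cc(N)c3nc2-c2ccccc2)cc1`, which in this assay gives 27500 nM; that step is an 8.7-fold higher number from compound 1 to compound 2 (0.94 log units; beyond the scatter), and it concerns a different place on the molecule, the group on the outer ring.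

On these data alone, compound 3 `Nc1cc(N)c2nc(-c3ccccc3)c(Oc3ccc(F)cc3)nc2c1` is untested. It differs from compound 1 in 4-fluorophenoxy in place of (4-fluorobenzyl)amino on an aromatic carbon. Among the compounds with values here, no measured step touches this linker, so nothing recorded bears directly on the change; the one known step shows only that numbers can move by a fair amount with small edits. The step from compound 1 to compound 3 is therefore expected to be a 1.9-fold higher number from compound 1 to compound 3 (0.28 log units; within the scatter), with wide uncertainty. Compound 3 is estimated at 6000 nM, within a range of 1500 nM to 25000 nM.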

Compound 3, concentration for total growth inhibition: < 100000 nM
Compound 3 ended at the assay's limit; the forecaster's own chance of this, stated with the estimate: 10%; the middle value is on the limit's open side.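

In this assay compound 3 gives < 100000 nM, which is a limit of the assay and not a number, so the step from compound 1 to compound 3 cannot be read: the limit of < 100000 nM in this assay, at which 1 of the 3 values shown sits.

On these data alone, whether 4-fluorophenoxy in place of (4-fluorobenzyl)amino strengthens or weakens growth inhibition stays open.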